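The source may report more compounds than this note shows. Statements on the series, on what has been measured and on what is new or still open speak of the compounds shown alone.

Measured in an assay on cells (Hepatocyte) for inhibition of glucokinase regulatory protein (Mus musculus), with stated times of 20 min and 40 min; on this read-out higher numbers stand for an effect only at larger amounts of compound and lower numbers for an effect already at smaller amounts:
Compound 1 `CC#C[C@H]1CN(S(=O)(=O)c2ccc(N)nc2)CCN1c1ncc(C(C)(O)C(F)(F)F)s1` — > 12500 nM, a limit.
Compound 2 `CC#C[C@H]1CN(S(=O)(=O)c2ccc(N)nc2)CCN1c1ccc(S(=O)(=O)Nc2ccccc2)cc1` — > 12500 nM, a limit.
Compound 3 `CC#C[C@H]1CN(S(=O)(=O)c2ccc(N)nc2)CCN1c1ccc(C(O)(COC)C(F)(F)F)cc1` — 202 nM.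

Within the data shown here, compound 3 stands as the only numeric value in this assay; the other two compounds sit at the limit of > 12500 nM in this assay, at which 2 of the 3 values shown sit. Compound 4 `CC#C[C@H]1CN(S(=O)(=O)c2ccc(N)nc2)CCN1c1ccc(C(C)=O)cc1` differs from compound 3 by a group of 3 heavy atoms (2 carbon, 1 oxygen; no ring) in place of a group of 9 heavy atoms (4 carbon, 2 oxygen, 3 fluorine; no ring), on an aromatic carbon. Among the measured compounds shown here, the only measured step at this position is an at least 61-fold lower number from compound 2 to compound 3 (1.79 log units; beyond the scatter), a large gain that came with the very group that compound 4 now loses; no step involving acetyl exists. The direction is therefore expected to be a loss, its size uncertain. Compound 4 is estimated at 3000 nM, between 500 nM and 12500 nM, which would mean an expected step of a 15-fold higher number from compound 3 to compound 4 (1.17 log units; beyond the scatter).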

Compound 4, half-maximal effective concentration: > 12500 nM
Compound 4: a limit, no number (the forecaster's own chance of this, stated with the estimate: 35%); at least 4.1-fold (0.61 log units) between middle value and limit.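

In this assay, acetyl in place of the larger group of compound 3 gives an at least 61-fold higher number from compound 3 to compound 4 (1.79 log units; beyond the scatter), so a carbonyl-bearing group of 3 heavy atoms on this aromatic carbon does not keep the effect, just as phenylsulfamoyl did not. The step between compound 2 and compound 4 cannot be read, since both values are limits. Only the group of compound 3 gives a number here, while the other compounds remain at a limit: the limit of > 12500 nM in this assay, at which 3 of the 4 values shown sit.

On these data alone, what stays open is which part of that group matters, with its hydroxyl, methoxymethyl and trifluoromethyl parts never separated. As far as these compounds go, whether an amine or a carboxylic acid on the same aromatic carbon would give a number also remains open.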